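Replacing an ester chain with a methoxyphenyl group

The compounds below may be only part of what the source reports. "The series", "measured", "known", "first", "only" and "open" are said of these compounds alone.

Compound 1 `Cc1ncsc1CCOC(=O)c1oc2cc(-c3ccccc3)cc(O)c2c1C` gives 0.055 ug/mL in a functional assay on WI-38 VA13 cells (Homo sapiens) for cytotoxicity (a lower number here means that less compound is needed, a higher number that more compound is needed for the effect), the lowest of the three numbers recorded so far. Compound 2 `Cc1c(C(=O)c2cccc(OC(C)C)c2)oc2cc(-c3ccccc3)cc(O)c12` gives 0.35 ug/mL and compound 3 `COc1ccc(C(=O)c2oc3cc(-c4ccccc4)cc(O)c3c2C)c(C(F)(F)F)c1` gives 0.4 ug/mL; both lie well beyond the scatter above compound 1. The unmeasured compound 4 `COc1ccccc1C(=O)c1oc2cc(-c3ccccc3)cc(O)c2c1C` differs from compound 1 in a single place: 2-methoxyphenyl in place of 2-(4-methyl-1,3-thiazol-5-yl)ethoxy on a carbonyl carbon. Like compound 2 and compound 3, compound 4 thus carries an aromatic ring directly on the carbonyl carbon. Because compound 2 gives 0.35 ug/mL and compound 3 gives 0.4 ug/mL, the number expected for compound 4 is 0.35 ug/mL, with a range of 0.1 ug/mL to 1.2 ug/mL. The expected step is a 6.4-fold higher number from compound 1 to compound 4 (0.80 log units; beyond the scatter), an increase beyond the scatter.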

Compound 4, half-maximal effective concentration: 0.09 ug/mL
Compound 4: middle estimate off by 3.9-fold (0.59 log units), on the high side, and the stated range ends above it.
By their numbers in this assay, from the lowest: compounds 1 and 4 (each within the scatter of the next); then compounds 2 and 3 (each within the scatter of the next).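

In this assay, the step, a 1.6-fold higher number from compound 1 to compound 4 (0.21 log units; within the scatter), shows that 2-methoxyphenyl can take the place of 2-(4-methyl-1,3-thiazol-5-yl)ethoxy on this carbonyl carbon without a difference beyond the scatter. In this pair, neither the thiazole ring nor the ester oxygen is needed to keep the number in that range. No data at hand bear on why the two groups give such close numbers. The compounds shown leave open whether an amine or a carboxylic acid on the 2-methoxyphenyl ring, or a longer chain in place of its methoxy group, would keep the number there.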